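A few compounds are considered here, and "the series" means these few. Any claim that something is new, unique, unknown or untested is made for them only; others in the source may bear on it.

Measured compounds:
- compound 1 `Cc1cc(NS(=O)(=O)c2ccc(N/C(S)=N\c3ccnc4cc(C(F)(F)F)ccc34)cc2)on1` — 60200 nM
- compound 2 `O=S(=O)(Nc1ncccn1)c1ccc(N/C(S)=N\c2ccnc3cc(C(F)(F)F)ccc23)cc1` — "not active" (no number reported)

Compound 1 was tested in a functional assay on HeLa cells (Homo sapiens) for antiproliferative activity, read by sulforhodamine B assay, with a stated time of 48 h (on this read-out higher numbers stand for weaker inhibition and lower numbers for stronger inhibition), where compound 1 gives 60200 nM. Compound 2 has no single number in this assay; for compound 2 the result is recorded only as "not active" (no number reported), so its standing cannot be placed on a scale against compound 1.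

Compound 3 `COc1ncnc(NS(=O)(=O)c2ccc(N/C(S)=N\c3ccnc4cc(C(F)(F)F)ccc34)cc2)c1OC` differs from compound 2 in one place: 5,6-dimethoxypyrimidin-4-yl in place of pyrimidin-2-yl on a sulfonamide nitrogen. Among the measured compounds shown here, no measured pair shows this change, so its effect is unknown. Given that compound 2 shows "not active" (no number reported), a weak result in this assay is expected for compound 3 as well, with a real chance that no single number is reported. The estimate for compound 3 in this assay is 80000 nM, within a range from 20000 nM to 300000 nM.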

Compound 3, half-maximal inhibitory concentration: "not active" (no number reported)
The entry for compound 3 holds no number; no gap can be computed for the estimate.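

Compound 2 and compound 3 are both recorded only as "not active", without a number, so no step can be read between them, and no evidence bears on this result. From the compounds shown here alone, the size of any effect of exchanging pyrimidin-2-yl for 5,6-dimethoxypyrimidin-4-yl stays open.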